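The source may report more compounds than this note shows. Statements on the series, on what has been measured and on what is new or still open speak of the compounds shown alone.

Three compounds of the series have so far been run through an ADME assay on microsomes from liver (Homo sapiens) for metabolic stability, with a stated time of 0.5 h, tested at 0.5 mg/mL; on this read-out lower numbers stand for a less stable compound and higher numbers for a more stable compound. Compound 1 `CN(C)C(=O)CCN1CCc2c(cc(-c3ccc(F)cc3)n2C)C1=O` returns only a limit of the read-out, > 100%, and that is all that can be said of it; (the limit of > 100% in this assay, at which 1 of the 3 values shown sits). Compound 2 `CC(=O)N1CC2(CC(NC(=O)c3cc(-c4ccc(F)cc4)no3)C2)C1` gives 84% in this assay. Compound 3 `CC(CNC(=O)c1cc(-c2ccc(F)cc2)no1)C(=O)N(C)C` gives 61% in this assay, the lowest of the two actual numbers available, with compound 2 standing higher by a margin beyond the usual scatter. For the measured compounds named here, no two measured compounds differ in a single place, so no isolated step has been quantified.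

Compound 4 `CN(C)C(=O)CCNC(=O)c1cc(-c2ccc(F)cc2)no1` remains to be measured in this assay. Relative to compound 3 the change is hydrogen in place of methyl on a saturated chain carbon bound to a carbonyl carbon and a saturated chain carbon. Going by the values given here, nothing among the measured compounds isolates this kind of change, so no measured step can be drawn on. The step is expected to be small, within the scatter, with no clear direction, and the expected step is a number 4 percentage points higher from compound 3 to compound 4 (within the scatter). Compound 4 is therefore estimated at 65%, within a range from 45% to 85%.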

Compound 4, percent of the compound remaining: 87%
Compound 4: middle estimate off by 22 percentage points, on the low side, and the stated range ends below it.
By their numbers in this assay, from the lowest: compound 3; then compounds 2 and 4 (each within the scatter of the next). At a limit, above all of these: compound 1.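

In this assay, hydrogen in place of methyl on a saturated chain carbon bound to a carbonyl carbon and a saturated chain carbon gives a number 26 percentage points higher from compound 3 to compound 4 (beyond the scatter). For the compounds shown here, this is the first single-place change with a quantified step, and it shows that this position is not silent: the loss of one methyl is enough to move the read-out beyond the scatter. Going by these compounds alone, nothing measured so far bears on what lies behind this step.

On these data alone, the step rests on a single pair of compounds, so whether it carries over to another chain or to another core remains open. Also open, as far as these compounds go, is what ethyl, a hydroxyl or an amine on this same carbon would give in this assay.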